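The source may report more compounds than this note shows. Statements on the series, on what has been measured and on what is new or still open speak of the compounds shown alone.

Of the compounds shown here, three have been measured in a functional assay on L1210 cells (Mus musculus) for antiproliferative activity; a lower number here means a stronger inhibitor, a higher number a weaker inhibitor: compound 1 `COc1cc(C(=O)c2sc(-c3cc(OC)c(OC)c(OC)c3)cc2N)cc(OC)c1OC` gives 2300 nM; compound 2 `COc1cc(C(=O)c2sc(-c3cccc([N+](=O)[O-])c3)cc2N)cc(OC)c1OC` gives 11 nM; compound 3 `COc1cc(C(=O)c2sc(-c3ccsc3)cc2N)cc(OC)c1OC` gives 12 nM. Compound 3 stands second highest of the three; its nearest neighbour is compound 2, whose number lies within the scatter of it, and its furthest is compound 1, whose number lies far beyond the scatter. Compound 4 `COc1cc(C(=O)c2sc(-c3ccccc3Cl)cc2N)cc(OC)c1OC` differs from compound 3 in one place: 2-chlorophenyl in place of thiophen-3-yl on an aromatic carbon. Among the compounds with values here, the only measured step that bears on this change is a 1.1-fold higher number from compound 2 to compound 3 (0.04 log units; within the scatter), in which one aromatic group on that aromatic carbon replaced another without a change beyond the scatter. For compound 4 the expected step is therefore a 1.5-fold higher number from compound 3 to compound 4 (0.18 log units; within the scatter), within the scatter. Compound 4 is estimated at 18 nM, in a range from 5 nM to 70 nM.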

Compound 4, half-maximal inhibitory concentration: 20 nM
Estimate against measurement, compound 4: 1.1-fold (0.05 log units) below, within the range that was stated.
By their numbers in this assay, from the lowest: compounds 2, 3 and 4 (each within the scatter of the next); then compound 1.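

In this assay, the aromatic carbon next to the ring sulfur now carries a third aromatic group that cannot be told apart from the other two: the change gives a 1.7-fold higher number from compound 3 to compound 4 (0.22 log units; within the scatter) and, set against 3-nitrophenyl, a 1.8-fold higher number from compound 2 to compound 4 (0.26 log units; within the scatter) as well. A six-membered aromatic ring of carbon only, bearing chlorine, thus stands with both the five-membered thiophen-3-yl and the nitro-bearing ring. No available evidence accounts for this result.

Going by these compounds, it remains open whether an amine or a longer chain on this carbon would give a similar number. On these data alone, what sets compound 1 apart from compounds 2, 3 and 4 also remains open.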